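The source may hold more compounds than are shown below. What is called first, only, known or untested is meant among the compounds shown, and "the series" means these compounds.

Measured in a functional assay on SMMC-7721 cells (Homo sapiens) for cytotoxicity, read by MTT assay, with a stated time of 72 h; on this read-out lower numbers stand for stronger inhibition and higher numbers for weaker inhibition:
- compound 1 `O=C1C(=Cc2cccc(Cl)c2)C(=O)N(c2ccc(Cl)cc2)N1c1ccc(Cl)cc1`: 20200 nM
- compound 2 `O=C1C(=C/C=C/c2ccccc2)C(=O)N(c2ccc(Cl)cc2)N1c1ccc(Cl)cc1`: 10100 nM

Going by the values given here, compound 2 is level, within the scatter, with compound 1, the only other compound measured. Next is compound 3 `O=C1C(=Cc2c[nH]c3ccccc23)C(=O)N(c2ccc(Cl)cc2)N1c1ccc(Cl)cc1`: 1H-indol-3-yl in place of 2-phenylethenyl on a double-bonded chain carbon bound to a double-bonded ring carbon. Here 1H-indol-3-yl stands in place of 2-phenylethenyl on a double-bonded chain carbon bound to a double-bonded ring carbon. Among the compounds with values here, one measured step bears on this place: a 2.0-fold lower number from compound 1 to compound 2 (0.30 log units; within the scatter), within the scatter. Within the data shown here, no indole-bearing compound has been measured, so the basis is thin, and no change beyond the scatter is expected in this assay. The estimated step is a 1.3-fold lower number from compound 2 to compound 3 (0.10 log units; within the scatter). For compound 3 the expected value is 8000 nM, with an estimated range of 2500 nM to 22000 nM.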

Compound 3, half-maximal inhibitory concentration: 19600 nM
Estimate against measurement, compound 3: 2.5-fold (0.39 log units) below; measured number inside the range.
By their numbers in this assay, from the lowest: compounds 2, 3 and 1 (each within the scatter of the next).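

In this assay the place on a double-bonded chain carbon bound to a double-bonded ring carbon now holds 3-chlorophenyl, 2-phenylethenyl and 1H-indol-3-yl, all level within the scatter. Bringing in 1H-indol-3-yl, with its five-membered aromatic ring and hydrogen-bond donor, separates it from neither 2-phenylethenyl (a 1.9-fold higher number from compound 2 to compound 3 (0.29 log units; within the scatter)) nor 3-chlorophenyl (a 1.0-fold lower number from compound 1 to compound 3 (0.01 log units; within the scatter)). No measured evidence bears on this result.

Open, going by these compounds, is whether an amine or a carboxylic acid at this place would move the number beyond the scatter. Changes elsewhere on the shared core also remain open.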